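From pyridin-4-yl to pyridin-2-yl: expected cytotoxicity

This account rests on a few compounds, and the source may have more. Where it says the series, first, only, none or still open, it means among the compounds named here.

Of the compounds shown here, three have been measured in an ADME assay on MT4 cells (Homo sapiens) for cytotoxicity, read by MTT assay, with a stated time of 4 days; a higher number here means that more compound is tolerated, a lower number that less compound is tolerated. Compound 1 `Cc1cc(C)cc(Cn2c(=O)cc(N=[N+]=[N-])n(Cc3ccncc3)c2=O)c1` gives 59000 nM. Compound 2 `CNc1cc(=O)n(Cc2cc(C)cc(C)c2)c(=O)n1Cc1ccccc1` gives 65000 nM in this assay. Compound 3 `Cc1cc(C)cc(Cn2c(=O)cc(N)n(Cc3ccncc3)c2=O)c1` reaches only the limit of this assay, reported as > 100000 nM, so for compound 3 there is a floor rather than a number. The one step that can be traced between two measured compounds is an at least 1.6-fold higher number from compound 1 to compound 3 (0.22 log units; that floor lies within the scatter); it rests on the limit shown by the limit of > 100000 nM in this assay, at which 1 of the 3 values shown sits, and its floor lies within the usual scatter.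

Compound 4 `Cc1cc(C)cc(Cn2c(=O)cc(N)n(Cc3ccccn3)c2=O)c1` differs from compound 3 by pyridin-2-yl in place of pyridin-4-yl on a saturated chain carbon bound to an aromatic nitrogen. For the measured compounds named here, no measured pair shows this change, so none of the measured steps bears on it; compounds 1 and 2 differ from compound 4 in other places as well. Going by the values given here, with nothing among the measured compounds pointing toward more or toward less tolerated compound, the expected step is a number no higher from compound 3 to compound 4 (the limit leaves the size open), that is, none beyond the scatter. Compound 4 is therefore estimated to give 100000 nM in this assay, between 50000 nM and 200000 nM, and it is expected that compound 4 too will most likely be reported only as a limit.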

Compound 4, half-maximal cytotoxic concentration: > 100000 nM
Compound 4: a limit, no number; the forecaster's own chance of this, stated with the estimate: 60%; the middle value sits exactly at the limit.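

In this assay compound 4 gives > 100000 nM as a limit and not a number. Compound 3 stands at the same limit, so no step can be read between compound 3 and compound 4: the limit of > 100000 nM in this assay, at which 2 of the 4 values shown sit. The compounds shown leave open whether pyridin-2-yl in place of pyridin-4-yl changes how much compound is tolerated.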